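The source may hold more compounds than are shown below. What is called first, only, known or untested is meant among the compounds shown, and "the series" means these compounds.

Measured so far:
compound 1 `Clc1ccc(Nc2ccnc(NCCNc3ccnc4cc(Cl)ccc34)n2)cc1`, 15800 nM in an ADME assay on Vero cells (Chlorocebus sabaeus) for cytotoxicity, read by neutral red uptake, with a stated time of 72 h; a higher number here means a weaker inhibitor, a lower number a stronger inhibitor
compound 2 `COc1ccc(Nc2ccnc(NCCNc3ccnc4cc(Cl)ccc34)n2)cc1`, "not active" (no number reported) in this assay

Compound 2 stands without a single number in this assay; of the two measured compounds only compound 1 gives a figure there. Compound 3 `COc1cc(Nc2ccnc(NCCNc3ccnc4cc(Cl)ccc34)n2)cc(OC)c1` differs from compound 2 by 3,5-dimethoxyphenyl in place of 4-methoxyphenyl on a nitrogen on an aromatic ring. For the measured compounds named here, no measured pair shows this change, so the size of the step is unknown. The starting point is a compound without a number, and compound 1 is itself weak, so the expectation is that compound 3 also stays weak in this assay, possibly again returning only a limit. Compound 3 is estimated at 30000 nM, with a range of 8000 nM to 100000 nM.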

Compound 3, half-maximal inhibitory concentration: "not active" (no number reported)
For compound 3 the study gives words and no number; no gap can be computed for the estimate.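

Compound 2 and compound 3 both return words without a number in this assay, so no step can be read between them. As far as these compounds go, whether 3,5-dimethoxyphenyl in place of 4-methoxyphenyl shifts the read-out at all stays open. Nothing available bears on a cause for these results.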